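Dropping One Trifluoromethyl Group: Expected Effect on Growth Inhibition

This account rests on a few compounds, and the source may have more. Where it says the series, first, only, none or still open, it means among the compounds named here.

Compound 1 `COc1cc(-c2nn(-c3cccc(NC(=O)Nc4cc(C(F)(F)F)cc(C(F)(F)F)c4)c3)cc2-c2ccncc2)ccc1Cl` gives 643 nM in a functional assay on HCT-116 cells (Homo sapiens) for inhibition, read by sulforhodamine B assay, with a stated time of 48 h; on this read-out higher numbers stand for weaker inhibition of growth and lower numbers for stronger inhibition of growth. Its only companion, compound 2 `O=C(Nc1cccc(-n2cc(-c3ccncc3)c(-c3ccc(Cl)c(O)c3)n2)c1)Nc1ccc(Cl)c(Cl)c1`, gives 1190 nM in this assay; the two numbers lie within the scatter of each other, so neither can be called the stronger. Compound 3 `COc1cc(-c2nn(-c3cccc(NC(=O)Nc4cccc(C(F)(F)F)c4)c3)cc2-c2ccncc2)ccc1Cl` carries hydrogen in place of trifluoromethyl on an aromatic carbon, leaving a single trifluoromethyl on that six-membered aromatic ring of carbon only. For the measured compounds named here, no measured pair shows this change, so the step is expected to be a modest weakening, probably not beyond the scatter: a 1.6-fold higher number from compound 1 to compound 3 (0.19 log units; within the scatter). Compound 3 is therefore expected to give about 1000 nM, between 400 nM and 2500 nM.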

Compound 3, concentration for 50% growth inhibition: 900 nM
Beside the measured number, compound 3's estimate is 1.1-fold (0.05 log units) above it; measured number inside the range.
By their numbers in this assay, from the lowest: compounds 1, 3 and 2 (each within the scatter of the next).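

In this assay the swap of one trifluoromethyl for hydrogen on this aromatic carbon gives a 1.4-fold higher number from compound 1 to compound 3 (0.15 log units; within the scatter) and so leaves the two compounds indistinguishable. At this position, then, a single trifluoromethyl on the ring is enough to keep growth inhibition in the same range as two. Nothing measured here gives a reason for this result.

From the compounds shown here alone, whether another group at this position, such as an amine or a carboxylic acid, would move the number beyond the scatter stays open. So does the effect of replacing the remaining trifluoromethyl with hydrogen as well.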